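The source may hold more compounds than are shown below. What is called first, only, known or untested is meant among the compounds shown, and "the series" means these compounds.

Of the compounds shown here, three sharing one core have been tested in an ADME assay on the whole organism for inhibition, with Echinochloa crus-galli var. formosensis as the target, with a stated time of 4 days; on this read-out lower numbers stand for stronger inhibition and higher numbers for weaker inhibition. Compound 1 `CCNc1nc(Cl)nc(N[C@@H](C)c2ccccc2)n1` gives 30900 nM, the highest of the three numbers. Compound 2 `CCNc1nc(Cl)nc(N[C@H](C)c2ccccc2)n1` gives 2690 nM, and the change an 11-fold lower number from compound 1 to compound 2 (1.06 log units; beyond the scatter) rests on the fact that compounds 1 and 2 differ only in the configuration as drawn alone. Compound 3 `CNc1nc(Cl)nc(N[C@H](C)c2ccccc2)n1` gives 562 nM, reached through the step of a 4.8-fold lower number from compound 2 to compound 3 (0.68 log units; beyond the scatter), a hydrogen replacing a methyl on a saturated chain carbon bound to a nitrogen on an aromatic ring.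

Compound 4 `CC[C@@H](C)Nc1nc(Cl)nc(N[C@@H](C)c2ccccc2)n1` has not been measured. It differs from compound 1 by ethyl in place of hydrogen on a saturated chain carbon bound to a nitrogen on an aromatic ring and a saturated chain carbon, so the ethylamino side grows to a (sec-butyl)amino side while the rest of compound 1, including its drawn configuration, stays. For the measured compounds named here, no measured step makes this same change. The nearest evidence is the step from compound 2 to compound 3, where a smaller group on a saturated chain carbon bound to a nitrogen on an aromatic ring gave the lower number; here the group grows instead, on the other side of the core, so a step of a 1.3-fold higher number from compound 1 to compound 4 (0.11 log units; within the scatter) toward a higher number is expected, small and near the scatter. Compound 4 is therefore estimated to give 40000 nM, between 12000 nM and 130000 nM.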

Compound 4, half-maximal inhibitory concentration: 7410 nM
Beside the measured number, compound 4's estimate is 5.4-fold (0.73 log units) above it; measured number below the stated range.
By their numbers in this assay, from the lowest: compound 3; then compound 2; then compound 4; then compound 1.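

The ethylamino group can be enlarged without raising the number: adding ethyl at this place, which turns it into (sec-butyl)amino, gives a 4.2-fold lower number from compound 1 to compound 4 (0.62 log units; beyond the scatter). Removing a methyl from the ethylamino group of compound 2 also lowered the number, a 4.8-fold lower number from compound 2 to compound 3 (0.68 log units; beyond the scatter), so in these two steps a smaller group and a larger one both moved this assay the same way, and no simple rule that smaller is better holds, although the two steps start from opposite drawn configurations of the shared core's other side chain. The sec-butyl group also brings a drawn stereocentre of its own, and configuration alone is already known to move the number in this series, as an 11-fold lower number from compound 1 to compound 2 (1.06 log units; beyond the scatter) shows: the fact that compounds 1 and 2 differ only in the configuration as drawn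

For the compounds shown here, what stays open is whether the drop belongs to the sec-butyl group as a whole or to its drawn configuration, and whether it would also appear with the opposite configuration on the other side chain, the one found in compound 2. A straight butylamino chain or a tert-butylamino group in the same place would help to tell whether branching or simply a larger chain goes with the lower number.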